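Shared-core series: cytotoxicity notes ahead of compound 4

The compounds below may be only part of what the source reports. "The series", "measured", "known", "first", "only" and "open" are said of these compounds alone.

Measured in an ADME assay on THP-1 cells (Homo sapiens) for cytotoxicity; on this read-out higher numbers stand for weaker inhibition and lower numbers for stronger inhibition:
compound 1 `COc1ccccc1-c1nnc(-c2ccc(C(=O)N/N=C/c3cc(O)ccc3O)cc2)o1` gives 100000 nM
compound 2 `COc1ccccc1-c1nnc(-c2ccc(C(=O)N/N=C/c3cccc([N+](=O)[O-])c3)cc2)o1` gives 119000 nM
compound 3 `COc1ccccc1-c1nnc(-c2ccc(C(=O)N/N=C/c3ccccc3O)cc2)o1` gives 207000 nM

Compound 3 holds the highest of the three numbers; its gap to compound 2, a 1.7-fold higher number from compound 2 to compound 3 (0.24 log units; within the scatter), is within the scatter, while a 2.1-fold higher number from compound 1 to compound 3 (0.32 log units; beyond the scatter) is modest but beyond it. Compound 4 `COc1ccc(/C=N/NC(=O)c2ccc(-c3nnc(-c4ccccc4OC)o3)cc2)cc1O` differs from compound 3 only at the aryl group: 3-hydroxy-4-methoxyphenyl in place of 2-hydroxyphenyl on a carbon with a double bond to nitrogen.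

For the measured compounds named here, the steps that bear on this are the aryl swaps a 1.2-fold higher number from compound 1 to compound 2 (0.08 log units; within the scatter) and a 1.7-fold higher number from compound 2 to compound 3 (0.24 log units; within the scatter), both within the scatter, and the hydroxy change a 2.1-fold higher number from compound 1 to compound 3 (0.32 log units; beyond the scatter), modest. Across these, changing this aryl group has barely moved this assay, so for compound 4 a step of a 1.4-fold lower number from compound 3 to compound 4 (0.14 log units; within the scatter) is expected, no larger than the scatter. Compound 4 is estimated at 150000 nM, between 70000 nM and 320000 nM.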

Compound 4, half-maximal inhibitory concentration: 260000 nM
Compound 4: middle estimate off by 1.7-fold (0.24 log units), on the low side; the measured number falls inside the stated range.
By their numbers in this assay, from the lowest: compounds 1, 2, 3 and 4 (each within the scatter of the next, the first and the last beyond it).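

In this assay, 3-hydroxy-4-methoxyphenyl in place of 2-hydroxyphenyl stays within the scatter (a 1.3-fold higher number from compound 3 to compound 4 (0.10 log units; within the scatter)), so this position takes the added methoxy without a readable shift. For the compounds shown here, the same group stands apart from 3-nitrophenyl (a 2.2-fold higher number from compound 2 to compound 4 (0.34 log units; beyond the scatter)), the first swap from that group to go beyond the scatter, and from 2,5-dihydroxyphenyl (a 2.6-fold higher number from compound 1 to compound 4 (0.41 log units; beyond the scatter)), though both steps are modest. No supporting data bear on the cause of these steps.

On these data alone, whether an aryl group carrying an amine or a carboxylic acid would shift this read-out further remains open. As far as these compounds go, the effect of changes to the shared core also remains open.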